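Adding a Pyrrolidinylmethyl Arm to the Triazole

This account rests on a few compounds, and the source may have more. Where it says the series, first, only, none or still open, it means among the compounds named here.

Compound 1, `O=C(O)c1ccc(-c2ccccc2C(=O)NCCCCCCCn2cc(-c3cccnc3)nn2)cc1`: 224 nM
Compound 2, `O=C(NCCCCCCCn1cc(-c2cccnc2)nn1)c1ccccc1-c1cccnc1`: 36.5 nM
Compound 3, `O=C(NCCCCCCCn1cc(-c2cccnc2)nn1)c1ccccc1-n1ccnn1`: 35.4 nM

In an ADME assay on SH-SY5Y cells (Homo sapiens) for cytotoxicity, read by MTT assay, with a stated time of 48 h (on this read-out lower numbers stand for an effect already at smaller amounts and higher numbers for an effect only at larger amounts of compound), compound 3 gives 35.4 nM, the lowest of the three numbers. The nearest is compound 2, whose 36.5 nM lies within the scatter of that number, so the two cannot be told apart. The furthest is compound 1, and the step of a 6.3-fold lower number from compound 1 to compound 3 (0.80 log units; beyond the scatter) lies beyond the scatter.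

Compound 4, `O=C(NCCCCCCCn1cc(-c2cccnc2)nn1)c1ccccc1-n1cc(CN2CCCC2)nn1`, differs from compound 3 in one place: (pyrrolidin-1-yl)methyl in place of hydrogen on an aromatic carbon. Among the measured compounds shown here, no measured step touches this position. The steps of a 6.1-fold lower number from compound 1 to compound 2 (0.79 log units; beyond the scatter) and a 6.3-fold lower number from compound 1 to compound 3 (0.80 log units; beyond the scatter) both concern the group on the other ring of the shared core, and the step of a 1.0-fold lower number from compound 2 to compound 3 (0.01 log units; within the scatter) shows that exchanging the two smaller groups there leaves the number unchanged within the scatter. Nothing here tells how a group added on the triazole itself would act, so the expectation rests on compound 3 alone, and the uncertainty is wide.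

The step of a 1.0-fold lower number from compound 3 to compound 4 (0.00 log units; within the scatter) is therefore estimated to stay within the scatter, with no clear direction. Compound 4 is expected to give 35 nM, within a range from 10 nM to 120 nM.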

Compound 4, half-maximal effective concentration: > 10000 nM
Compound 4 was reported as a limit; the forecaster's own chance of this, stated with the estimate: 5%; at least 280-fold (2.45 log units) between middle value and limit.
By their numbers in this assay, from the lowest: compounds 3 and 2 (each within the scatter of the next); then compound 1. At a limit, above all of these: compound 4.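

In this assay, among the compounds shown here, the aromatic carbon of the five-membered aromatic ring with 3 nitrogen, which no earlier step touched, proves highly sensitive to substitution: putting (pyrrolidin-1-yl)methyl in place of hydrogen there gives an at least 280-fold higher number from compound 3 to compound 4 (2.45 log units; beyond the scatter). Comparisons with the two other compounds point the same way, with an at least 270-fold higher number from compound 2 to compound 4 (2.43 log units; beyond the scatter) and an at least 44-fold higher number from compound 1 to compound 4 (1.64 log units; beyond the scatter), so the new arm moves the number further than any exchange of groups among compounds 1, 2 and 3, and on this read-out the effect of compound 4 appears only at much larger amounts. Compound 4 stands at a limit and not at a number, so each of these steps gives only a minimum size: the limit of > 10000 nM in this assay, at which 1 of the 4 values shown sits.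

The compounds shown do not tell whether this jump needs the amine and its ring, since a plain methyl, a hydroxymethyl or an open-chain dimethylaminomethyl on the same carbon would be required to separate these parts. They also leave open how a longer chain between the amine and the aromatic ring would act, and whether the arm would have the same effect alongside a carboxylic acid elsewhere on the shared core.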